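The source may hold more compounds than are shown below. What is called first, only, known or untested is meant among the compounds shown, and "the series" means these compounds.

Compound 1 `COc1cccc(NC(=S)Nc2cccc(C(F)(F)F)c2)c1` gives 20000 nM in an ADME assay on Vero 76 cells (Chlorocebus sabaeus) for cytotoxicity, read by crystal violet staining, with a stated time of 96 h; a lower number here means that less compound is tolerated, a higher number that more compound is tolerated.
Compound 2 `CCNC(=S)Nc1cccc(C(F)(F)F)c1` reaches only a limit of this assay, > 100000 nM.
Compound 3 `FC(F)(F)c1cccc(NC(=S)NCc2ccco2)c1` gives 50000 nM in this assay.

Compound 3 stands highest of the two numbers shown; compound 1, the other number and the nearest one, gives 20000 nM. Compound 4 `Fc1cccc(NC(=S)Nc2cccc(C(F)(F)F)c2)c1` differs from compound 3 in one place: 3-fluorophenyl in place of (furan-2-yl)methyl on an amide-type nitrogen. Among the compounds with values here, the only measured step on this nitrogen is an at least 2.0-fold lower number from compound 2 to compound 3 (0.30 log units; that floor lies within the scatter), which lowered the number, though only as far as a limit allows. Compound 4 carries an aromatic ring directly on that nitrogen, as compound 1 does, and compound 1 gives a lower number than compound 3 in this assay. A moderate decrease is therefore expected, a 2.0-fold lower number from compound 3 to compound 4 (0.30 log units; within the scatter). Compound 4 is estimated at 25000 nM, within 10000 nM to 70000 nM.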

Compound 4, half-maximal cytotoxic concentration: 20000 nM
The estimate for compound 4 lay 1.3-fold (0.10 log units) above the measured number; low and high end bracket the measured number.
By their numbers in this assay, from the lowest: compounds 1 and 4 (each within the scatter of the next); then compound 3. At a limit, above all of these: compound 2.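

In this assay, 3-fluorophenyl on this amide-type nitrogen gives a 2.5-fold lower number from compound 3 to compound 4 (0.40 log units; beyond the scatter) in place of (furan-2-yl)methyl, and an at least 5.0-fold lower number from compound 2 to compound 4 (0.69 log units; beyond the scatter) in place of ethyl. Compound 2 stands at a limit, not a number: the limit of > 100000 nM in this assay, at which 1 of the 4 values shown sits.
With an aromatic ring on the nitrogen, fluoro in place of methoxy on an aromatic carbon gives no change at the digits printed from compound 1 to compound 4 (within the scatter), so this exchange leaves the number unmoved.

The compounds shown leave open whether an amine or a carboxylic acid on that aromatic carbon would move the number. They also leave open what a longer chain on the amide-type nitrogen would do.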